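The source may hold more compounds than are shown below. What is called first, only, known or untested is meant among the compounds shown, and "the series" means these compounds.

Measured so far:
compound 1 `Cc1cc(C)nc(-n2nc(C)c3c2NC(=O)CC3c2ccc(F)cc2F)n1`: > 10000 nM in a functional assay on HEK293 cells for agonist activity at G-protein coupled receptor 39 (Homo sapiens), read by scintillation proximity assay and inositol phosphate accumulation, with a stated time of 75 min; a lower number here means that less compound is needed, a higher number that more compound is needed for the effect
compound 2 `Cc1nn(-c2ncnc3nc[nH]c23)c2c1C(OC(=O)c1ccc(F)cc1)CC(=O)N2`: 245 nM in this assay

For compound 1 the entry > 10000 nM is a limit of this assay, not a number. Going by the values given here, compound 2 holds the only number in the set with 245 nM. The other entry is the limit (the limit of > 10000 nM in this assay, at which 1 of the 2 values shown sits). Compound 3 `Cc1nn(-c2ncnc3nc[nH]c23)c2c1C(OCc1ccc(F)cc1)CC(=O)N2` awaits measurement in this assay. It differs from compound 2 in one place: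

4-fluorobenzyl in place of (4-fluorophenyl)carbonyl on an oxygen on a saturated carbon

Among the compounds with values here, no step between measured compounds is available, so the size of this step cannot be read from the series. A modest loss beyond the scatter is expected, a 2.4-fold higher number from compound 2 to compound 3 (0.39 log units; beyond the scatter). Compound 3 is therefore estimated at 600 nM, with a range from 150 nM to 3000 nM.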

Compound 3, half-maximal effective concentration: 126 nM
Compound 3: the middle estimate sits 4.8-fold (0.68 log units) above what was measured; measured number below the stated range.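

Replacing (4-fluorophenyl)carbonyl with 4-fluorobenzyl on the oxygen on a saturated carbon gives a 1.9-fold lower number from compound 2 to compound 3 (0.29 log units; within the scatter) in this assay and so leaves the response in place. In this pair, the carbonyl of the leaving group is therefore not required for a measurable response. No measured property bears on why the two groups read alike.

From the compounds shown here alone, whether the fluorophenyl ring itself is needed at this oxygen remains open. A plain methyl or a chain ending in an amine on the same oxygen would address that.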